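From Methylsulfonyl to Trifluoromethyl in Rat Aorta

A few compounds are considered here, and "the series" means these few. Any claim that something is new, unique, unknown or untested is made for them only; others in the source may bear on it.

Compound 1 `CN(C)/C(=N\C#N)C1=CC(C)(C)Oc2ccc([N+](=O)[O-])cc21`: "nt" (no result reported)
Compound 2 `CN(C)/C(=N\C#N)C1=CC(C)(C)Oc2ccc(S(=O)(=O)c3ccccc3)cc21`: 73.8%
Compound 3 `CN(C)/C(=N\C#N)C1=CC(C)(C)Oc2ccc(S(C)(=O)=O)cc21`: "nt" (no result reported)

Three compounds share one core and differ only in the group carried on the aromatic ring. In a functional assay on the whole organism (aorta) with Rattus norvegicus as the target (a lower number here means a smaller maximal response, a higher number a larger maximal response), only compound 2 has a number: compound 2 reaches 73.8%. Among the measured compounds shown here, compound 1 and compound 3 carry no result in this assay, so compound 3 stands without any number of its own; it gives nothing to compare against and no step from it to another measured compound can be drawn.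

Compound 4 `CN(C)/C(=N\C#N)C1=CC(C)(C)Oc2ccc(C(F)(F)F)cc21` is the next compound. It arises from compound 3 by a single change, (trifluoromethyl in place of methylsulfonyl on an aromatic carbon). For the measured compounds named here, since compound 3 has no value, the size and direction of this step in this assay cannot be taken from the data; the only anchor is compound 2 with its 73.8%, a compound that carries a different group at the same place. A maximal response of a similar order is expected for compound 4, and the uncertainty is wide. Compound 4 is therefore expected to give about 78% in this assay, within a range from 50% to 100%.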

Compound 4, intrinsic activity: the largest response reached, in percent of the reference agonist's: 75.2%
Compound 4: middle estimate off by 2.8 percentage points, on the high side; the range from low to high includes it.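

Changing the group at this position does not have to shift the maximal response. In this assay the exchange of phenylsulfonyl for trifluoromethyl on the aromatic carbon gives a number 1.4 percentage points higher from compound 2 to compound 4 (within the scatter) and so the two compounds cannot be told apart in this read-out, even though one group carries a ring of its own and the other, with no ring and no hydrogen-bond acceptors, is built quite differently. The direct change from methylsulfonyl to trifluoromethyl still cannot be read, as compound 3 has no number, and nothing measured here offers an explanation for the match between compound 2 and compound 4.

With only two numbers, this is a single comparison and not a rule for the position, and the compounds shown say nothing about how far this tolerance extends. Going by these compounds, it remains open whether an amine, a carboxylic acid or a longer chain such as butyl at this aromatic carbon would keep the response in this assay or change it, and whether the shared core would give a response at all with a plain hydrogen there.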